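This account rests on a few compounds, and the source may have more. Where it says the series, first, only, none or still open, it means among the compounds named here.

Measured in an ADME assay on HEK-293T cells (Homo sapiens) for cytotoxicity; a higher number here means that more compound is tolerated, a lower number that less compound is tolerated:

Compound 1 `CC(C)CN(NC(=O)C1CCC2(CC1)OOC1(OO2)C2CC3CC(C2)CC1C3)c1cc(Cl)nc(C#N)n1`: > 100000 nM, a limit of the assay
Compound 2 `CC(C)CN(NC(=O)C1CCC2(CC1)OOC1(OO2)C2CC3CC(C2)CC1C3)c1nc(C#N)ncc1Cl`: > 100000 nM, a limit of the assay

Compound 2 stands at a limit and has no exact number. Within the data shown here, the only other value, that of compound 1, is also a limit, and the limit of > 100000 nM in this assay, at which 2 of the 2 values shown sit, sums up this position. Among the measured compounds shown here, the one measured step, a step that the two limits leave unreadable from compound 1 to compound 2, therefore gives no size to carry forward.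

Compound 3 `CC(C)CN(NC(=O)C1CCC2(CC1)OOC1(OO2)C2CC3CC(C2)CC1C3)c1ccnc(C#N)n1` differs from compound 2 by one change, (hydrogen in place of chloro on an aromatic carbon). It has hydrogen in place of chloro on an aromatic carbon, turning 5-chloro-2-cyanopyrimidin-4-yl into 2-cyanopyrimidin-4-yl.

The expectation for this change rests on compound 2 and its limit of > 100000 nM. For the measured compounds named here, no measured step shows what removing chloro does, so no direction can be given, and no step beyond the scatter is expected in this assay. Compound 3 may well be reported as a limit too. The expected change is a number no higher from compound 2 to compound 3 (the limit leaves the size open), an estimate only. For compound 3 the estimated value is 100000 nM, with an expected range from 50000 nM to 200000 nM.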

Compound 3, half-maximal cytotoxic concentration: > 100000 nM
Compound 3 was reported as a limit (the forecaster's own chance of this, stated with the estimate: 85%); the middle value sits exactly at the limit.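

Compound 3 gives > 100000 nM in this assay, and this is a limit of the assay, not an exact number. Its steps from compound 1 and from compound 2 cannot be read, so no size can be given: the limit of > 100000 nM in this assay, at which 3 of the 3 values shown sit.

What the compounds shown leave open is how far any of the three could differ in cytotoxicity, since none has an exact value.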